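A methyl group on the phenyl of compound 2

The source may report more compounds than this note shows. Statements on the series, on what has been measured and on what is new or still open speak of the compounds shown alone.

In an ADME assay on Vero cells (Chlorocebus sabaeus) for cytotoxicity, read by crystal violet staining, with a stated time of 72 h (a higher number here means that more compound is tolerated, a lower number that less compound is tolerated), compound 1 `COc1cc(-c2ccc(C(=O)NNC(=S)Nc3ccc(Cl)cc3)c(C)n2)cc(OC)c1OC` gives 523000 nM and compound 2 `COc1cc(-c2ccc(C(=O)NNC(=S)Nc3ccccc3)c(C)n2)cc(OC)c1OC` gives 513000 nM. Going by the values given here, these two values lie within the scatter of each other, so compound 2 stands level with its only measured neighbour, and the series offers no real spread so far. Compound 3 `COc1cc(-c2ccc(C(=O)NNC(=S)Nc3ccc(C)cc3)c(C)n2)cc(OC)c1OC` departs from compound 2 in one place: methyl in place of hydrogen on an aromatic carbon. In words, this is methyl in place of hydrogen on an aromatic carbon, para to a large group. Among the compounds with values here, only one measured step bears on this change, the swap of chloro for hydrogen on an aromatic carbon, which came to a 1.0-fold lower number from compound 1 to compound 2 (0.01 log units; within the scatter). No methyl compound has yet been measured, so this evidence is thin, but it gives no reason to expect movement. The estimated step of a 1.0-fold lower number from compound 2 to compound 3 (0.00 log units; within the scatter) is therefore expected to stay within the scatter. For compound 3 the expected value is 510000 nM, with an estimated range from 280000 nM to 900000 nM.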

Compound 3, half-maximal cytotoxic concentration: 574000 nM
The estimate for compound 3 lay 1.1-fold (0.05 log units) below the measured number; the range from low to high includes it.
By their numbers in this assay, from the lowest: compounds 2, 1 and 3 (each within the scatter of the next).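

In this assay, a methyl group at this place brings a 1.1-fold higher number from compound 2 to compound 3 (0.05 log units; within the scatter), and methyl in place of chloro brings a 1.1-fold higher number from compound 1 to compound 3 (0.04 log units; within the scatter). The position has now carried hydrogen, chloro and methyl, on an aromatic carbon para to a large group, and compound 1, compound 2 and compound 3 all stand level, so the methyl swap adds a second kind of substituent to the chloro swap without any step leaving the scatter. Nothing available explains this levelness, and no supporting measurement bears on it.

From the compounds shown here alone, whether a group of another kind at this place, such as an amine, a carboxylic acid or a longer chain, would also stay level remains open. Going by these compounds, all the steps shown sit at this one place, so the effect of changes elsewhere on the shared core also stays open.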